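Nucleoside series: furan-3-yl for thiophen-2-yl, compound 3 to 4

The compounds below may be only part of what the source reports. "The series", "measured", "known", "first", "only" and "open" are said of these compounds alone.

Measured so far:
- compound 1, `Nc1nc2c(c(-c3ccccc3)cn2[C@@H]2O[C@H](CO)[C@@H](O)[C@H]2O)c(=O)[nH]1`, returns only a limit, > 100000 nM, in a functional assay on CCRF-CEM cells (Homo sapiens), read by MTT assay, with a stated time of 72 h; a higher number here means a weaker inhibitor, a lower number a stronger inhibitor.
- compound 2, `O=c1[nH]cnc2c1c(-c1ccco1)cn2[C@@H]1O[C@H](CO)[C@@H](O)[C@H]1O`, returns only a limit, > 20000 nM, in this assay.
- compound 3, `Cc1nc(N)c2c(-c3cccs3)cn([C@@H]3O[C@H](CO)[C@@H](O)[C@H]3O)c2n1`, returns only a limit, > 20000 nM, in this assay.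

Going by the values given here, compound 3 stands at a limit rather than at a number in this assay; that limit is shared, as the limit of > 20000 nM in this assay, at which 2 of the 3 values shown sit, shows, and the one other value shown sits at a different limit, (the limit of > 100000 nM in this assay, at which 1 of the 3 values shown sits). Among the compounds with values here, no number is known for any compound, so no measured step can be set down.

Compound 4, `Cc1nc(N)c2c(-c3ccoc3)cn([C@@H]3O[C@H](CO)[C@@H](O)[C@H]3O)c2n1`, differs from compound 3 in one place: furan-3-yl in place of thiophen-2-yl on an aromatic carbon.

With nothing in the series having reached a number in this assay, the step from compound 3 to compound 4 is expected to be none beyond the scatter, and compound 4 is expected to sit at a limit as well; the estimated step is a step that the limit leaves unreadable from compound 3 to compound 4.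

Compound 4 is therefore expected at 50000 nM in this assay, within a range of 20000 nM to 200000 nM.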

Compound 4, half-maximal inhibitory concentration: > 100000 nM
Compound 4 was reported as a limit (the forecaster's own chance of this, stated with the estimate: 85%); at least 2.0-fold (0.30 log units) between middle value and limit.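

Going by these compounds alone, compound 3 and compound 4 both return only limits in this assay, and no step between them can be read. The compounds shown leave open whether any change to the shared core brings a compound of this series to a number in this assay.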